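Chloropropyl urea on the sulfonate core

A few compounds are considered here, and "the series" means these few. Any claim that something is new, unique, unknown or untested is made for them only; others in the source may bear on it.

Compound 1, `CCCC(=O)Nc1ccc(S(=O)(=O)Oc2ccccc2C(C)C)cc1`: 6600 nM
Compound 2, `CCNC(=O)Nc1ccc(S(=O)(=O)Oc2ccccc2C(C)C)cc1`: 10000 nM
Compound 3, `CCCCCNC(=O)Nc1ccc(S(=O)(=O)Oc2ccccc2C(C)C)cc1`: 4000 nM

In a functional assay on MCF7 cells (Homo sapiens) for antiproliferative activity, read by sulforhodamine B assay, with a stated time of 48 h (on this read-out higher numbers stand for weaker inhibition and lower numbers for stronger inhibition), compound 3 gives the lowest of the three numbers; the steps to it read a 2.5-fold lower number from compound 2 to compound 3 (0.40 log units; beyond the scatter) and a 1.7-fold lower number from compound 1 to compound 3 (0.22 log units; within the scatter). Compound 4, `CC(C)c1ccccc1OS(=O)(=O)c1ccc(NC(=O)NCCCCl)cc1`, differs from compound 3 by chloro in place of ethyl on a saturated chain carbon, three bonds along the chain from an amide-type nitrogen. The step that bears on it is a 2.5-fold lower number from compound 2 to compound 3 (0.40 log units; beyond the scatter), a modest gain for a longer urea chain; compound 4 keeps a 3-chloropropyl chain, shorter than pentyl, so part of that gain may be lost. The step from compound 3 to compound 4 is therefore expected to stay small, within the scatter: a 1.4-fold higher number from compound 3 to compound 4 (0.14 log units; within the scatter). Compound 4 is estimated at 5500 nM, with a range of 2500 nM to 12000 nM.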

Compound 4, half-maximal inhibitory concentration: 7400 nM
Compound 4: the middle estimate sits 1.3-fold (0.13 log units) below what was measured; measured number inside the range.
By their numbers in this assay, from the lowest: compounds 3, 1, 4 and 2 (each within the scatter of the next, the first and the last beyond it).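

In this assay, chloro in place of ethyl on this chain carbon stays within the scatter (a 1.9-fold higher number from compound 3 to compound 4 (0.27 log units; within the scatter)), so the 3-chloropropyl chain cannot be told apart from pentyl here. The other two steps are also within the scatter (a 1.4-fold lower number from compound 2 to compound 4 (0.13 log units; within the scatter); a 1.1-fold higher number from compound 1 to compound 4 (0.05 log units; within the scatter)), which places this chain level with all three earlier ureas and amides, even though the ethyl and pentyl ureas stand apart. Nothing available explains these results. As far as these compounds go, whether an amine or a hydroxyl at the end of this chain would move the number remains open. So does whether a longer chain carrying chloro would.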